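The source may hold more compounds than are shown below. What is called first, only, known or untested is meant among the compounds shown, and "the series" means these compounds.

Of the compounds shown here, three have been tested in a functional assay on WI-38 cells (Homo sapiens) for inhibition; on this read-out lower numbers stand for stronger inhibition and higher numbers for weaker inhibition. Compound 1 `CCC(C)C(NC(=O)NO)C(=O)NC1CCCCC1` reaches only the assay limit, giving > 100000 nM. Compound 2 `CCC(C)C(NC(=O)n1nnc2ccccc21)C(=O)NC1CCCCC1` likewise reaches only the limit, giving > 100000 nM. Compound 3 `CCC(C)C1NC(=O)N(Cc2ccccc2)C1=O` does give a measured number, 74100 nM. Compound 2 therefore stands at the limit of > 100000 nM in this assay, at which 2 of the 3 values shown sit, which is a limit and not a number.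

Compound 4 `CCC(C)C(NC(=O)n1nnc2ccccc21)C(=O)NC1CCCC1` differs from compound 2 in one place: cyclopentyl in place of cyclohexyl on an amide-type nitrogen. Going by the values given here, no measured pair shows what this change does, and the starting point is itself a limit. Compound 2 is expected to stay essentially where it is, so the step is expected at a step that the limit leaves unreadable from compound 2 to compound 4, no more than scatter. Compound 4 is expected to give about 150000 nM, within a range of 50000 nM to 500000 nM.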

Compound 4, half-maximal inhibitory concentration: > 100000 nM
Compound 4: a limit, no number (the forecaster's own chance of this, stated with the estimate: 85%); the middle value lies beyond the limit too.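

Going by these compounds alone, compound 2 and compound 4 each give only a limit, not a number, and no step between them can be read. From the compounds shown here alone, whether cyclopentyl in place of cyclohexyl on the amide-type nitrogen changes inhibition at all remains open.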